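Replacing (4-chlorobenzyl)amino with pyrrolidin-1-yl on the shared core

The compounds below may be only part of what the source reports. "The series", "measured", "known", "first", "only" and "open" are said of these compounds alone.

Three amides built on one shared core have been tested in a functional assay on HeLa cells (Homo sapiens) for antiproliferative activity, read by sulforhodamine B assay, with a stated time of 48 h; a lower number here means a stronger inhibitor, a higher number a weaker inhibitor. Among them, compound 1 (`COc1ccc(C[C@@H](O)/C=C/C=C/C(=O)NCc2ccc(Cl)cc2)cc1OC`) gives 13400 nM. Compound 2 (`COc1ccc(C[C@@H](O)/C=C/C=C/C(=O)N2CCN(C(c3ccccc3)c3ccccc3)CC2)cc1OC`) gives 10500 nM, and compound 3 (`COc1ccc(C[C@@H](O)/C=C/C=C/C(=O)NCc2cc(OC)c(OC)c(OC)c2)cc1OC`) gives 10700 nM. Compound 1 therefore stands level with both of the others, all within the scatter.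

Compound 4 (`COc1ccc(C[C@@H](O)/C=C/C=C/C(=O)N2CCCC2)cc1OC`) has not yet been measured. It carries pyrrolidin-1-yl in place of (4-chlorobenzyl)amino on a carbonyl carbon. Within the data shown here, no measured pair differs in one place only, so no direct step guides this change.

In this assay, no step beyond the scatter is expected, and neither direction is favoured. This expectation rests on compound 3 at 10700 nM and compound 2 at 10500 nM, whose different amide groups leave them within the scatter of compound 1. The estimated change is a 1.1-fold higher number from compound 1 to compound 4 (0.05 log units; within the scatter). Compound 4 is expected at 15000 nM, with an estimated range from 7000 nM to 40000 nM.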

Compound 4, half-maximal inhibitory concentration: 14100 nM
Compound 4: middle estimate off by 1.1-fold (0.03 log units), on the high side, and the stated range covers the measured number.
By their numbers in this assay, from the lowest: compounds 2, 3, 1 and 4 (each within the scatter of the next).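

In this assay, among these compounds, the first direct step at this position, on a carbonyl carbon, is a 1.1-fold higher number from compound 1 to compound 4 (0.02 log units; within the scatter) and so shows no measurable change. Pyrrolidin-1-yl replaces (4-chlorobenzyl)amino here, so the six-membered aromatic ring and the hydrogen-bond donor both leave in one exchange, and this pair still stands level. No measurement given here bears on why these two amides stand level.

Compounds 1 to 4 leave open whether any amide group at this position can move the number beyond the scatter, for instance a morpholine ring, a benzyl group bearing a primary amine, or a chain ending in a carboxylic acid. They also leave open how the aromatic ring and the hydrogen-bond donor would each count if exchanged separately.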